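Fluoro for Iodo: Expected Hemolysis of Compound 3

The compounds below may be only part of what the source reports. "The series", "measured", "known", "first", "only" and "open" are said of these compounds alone.

Compound 1 `CC(=NNC(=S)Nc1cccc(I)c1)c1ccccn1` gives > 10000 nM in an ADME assay on cells (Erythrocyte, Homo sapiens), read by hemolysis, with a stated time of 1 h (on this read-out higher numbers stand for weaker inhibition and lower numbers for stronger inhibition), a limit of the assay rather than a number.
Compound 2 `CC(=NNC(=S)Nc1ccc([N+](=O)[O-])cc1)c1ccccn1` gives > 10000 nM in this assay, again only a limit.

Compound 1 stands at the limit of > 10000 nM in this assay, at which 2 of the 2 values shown sit. Compound 3 `CC(=NNC(=S)Nc1cccc(F)c1)c1ccccn1` differs from compound 1 by fluoro in place of iodo on an aromatic carbon. Among the compounds with values here, no measured step between two compounds is available to lean on, so in this assay no shift beyond the scatter is expected in either direction. Compound 3 is therefore expected to give 15000 nM, with a range from 5000 nM to 50000 nM, and most likely again only as a limit. The step that the limit leaves unreadable from compound 1 to compound 3 is estimated to be flat.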

Compound 3, half-maximal inhibitory concentration: > 10000 nM
Compound 3: only a limit was reported (the forecaster's own chance of this, stated with the estimate: 85%); the middle value does not contradict the limit.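

No step can be read from compound 1 to compound 3, since both are reported only as limits: the limit of > 10000 nM in this assay, at which 3 of the 3 values shown sit.

The compounds shown leave open whether fluoro and iodo differ at all in this assay and what actual value any of these compounds would give.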